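From Cyclopropyl to Hydroxymethyl: One Untested Step

The source may report more compounds than this note shows. Statements on the series, on what has been measured and on what is new or still open speak of the compounds shown alone.

Compound 1 `CC(=O)Nc1ccc(-c2nn(Cc3ccc(C#N)cc3)c(=O)c3ccccc23)c(F)n1`: > 100000 nM (a limit of the assay)
Compound 2 `O=c1c(C2CC2)cc(-c2ccc(F)nc2F)nn1Cc1ccc(Cl)cc1`: 39800 nM

Of the compounds shown here, two have so far been tested in an ADME assay on HepG2 2.2.15 cells (Homo sapiens) for cytotoxicity, read by MTT assay, with a stated time of 8 days; a higher number here means that more compound is tolerated, a lower number that less compound is tolerated. Compound 1 gives no number, only a limit of > 100000 nM. For the measured compounds named here, compound 2, at 39800 nM, therefore holds the only actual number in the set, so its standing rests on a single reading with no firm neighbour to compare it with.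

The next compound, compound 3 `O=c1c(CO)cc(-c2ccc(F)nc2F)nn1Cc1ccc(Cl)cc1`, differs from compound 2 in one place, with hydroxymethyl in place of cyclopropyl on an aromatic carbon. Going by the values given here, no measured pair shows a change of this kind, so any forecast is tentative. A modest move toward more compound being tolerated is expected, and it may not clear the usual scatter by much. The expected change is a 1.6-fold higher number from compound 2 to compound 3 (0.21 log units; within the scatter), and this is an estimate only. A reading reported as a limit would not be surprising, as the limit of > 100000 nM in this assay, at which 1 of the 2 values shown sits, shows. Compound 3 is estimated at 65000 nM, with an expected range of 30000 nM to 100000 nM.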

Compound 3, half-maximal cytotoxic concentration: > 100000 nM
Compound 3 ended at the assay's limit; the forecaster's own chance of this, stated with the estimate: 40%; middle value at least 1.5-fold (0.18 log units) away from the limit.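

In this assay, for the compounds shown here, the exchange of cyclopropyl for hydroxymethyl on this aromatic carbon gives the first readable step at this position, and it is an at least 2.5-fold higher number from compound 2 to compound 3 (0.40 log units; beyond the scatter). For compound 3, the reading of > 100000 nM is a limit of the assay and not a number. The step therefore fixes a direction and only a lower bound on its size, and this assay now leaves little room for reading changes that move further the same way: the limit of > 100000 nM in this assay, at which 2 of the 3 values shown sit.

Going by these compounds, whether the step follows from the departure of the cyclopropyl ring or from the arrival of the hydroxyl oxygen stays open, and a methyl or a methoxymethyl on the same aromatic carbon would tell those two apart. On these data alone, how far a group such as an aminomethyl or a carboxylic acid at this position would shift the reading is also open, as is whether any change here would bring the reading below the limit of the assay and give a number that could be compared with that of compound 2.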